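Benzyl ether variation on the isoxazole-piperazine series

The source may hold more compounds than are shown below. What is called first, only, known or untested is meant among the compounds shown, and "the series" means these compounds.

Measured so far:
compound 1 `Cc1ccccc1COc1ccc(-c2cc(CN3CCN(Cc4ccc(C(F)(F)F)cc4)CC3)no2)cc1` — 3700 nM
compound 2 `N#Cc1ccccc1COc1ccc(-c2cc(CN3CCN(Cc4ccc(C(F)(F)F)cc4)CC3)no2)cc1` — 4000 nM
compound 3 `N#Cc1ccc(COc2ccc(-c3cc(CN4CCN(Cc5ccc(C(F)(F)F)cc5)CC4)no3)cc2)cc1` — 100 nM

In a functional assay on MCF7 cells (Homo sapiens) for antiproliferative activity, read by sulforhodamine B assay, with a stated time of 72 h (on this read-out higher numbers stand for weaker inhibition and lower numbers for stronger inhibition), compound 1 gives 3700 nM, the second highest of the three numbers. Its nearest neighbour is compound 2: a 1.1-fold higher number from compound 1 to compound 2 (0.03 log units; within the scatter). For the measured compounds named here, the only large step in the set leads to compound 3: a 37-fold lower number from compound 1 to compound 3 (1.57 log units; beyond the scatter), and likewise a 40-fold lower number from compound 2 to compound 3 (1.60 log units; beyond the scatter). So exchanging the substitution on the benzyl ether ring has, in one case, moved the number far; in another, not at all.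

Compound 4 `COc1cc(COc2ccc(-c3cc(CN4CCN(Cc5ccc(C(F)(F)F)cc5)CC4)no3)cc2)cc(OC)c1OC` is not yet measured. It differs from compound 1 by 3,4,5-trimethoxyphenyl in place of 2-methylphenyl on a saturated chain carbon bound to an oxygen on an aromatic ring. Going by the values given here, no measured compound carries a 3,4,5-trimethoxyphenyl, so no step bears directly on it; the steps to compound 3 show only that this part of the molecule can shift the number strongly, while the step to compound 2 shows it need not. A moderate lowering is expected, a 7.4-fold lower number from compound 1 to compound 4 (0.87 log units; beyond the scatter), with wide uncertainty. Compound 4 is estimated at 500 nM, in the range 80 nM to 3000 nM.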

Compound 4, half-maximal inhibitory concentration: 1800 nM
Estimate against measurement, compound 4: 3.6-fold (0.56 log units) below; the measured number falls inside the stated range.
By their numbers in this assay, from the lowest: compound 3; then compound 4; then compounds 1 and 2 (each within the scatter of the next).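

In this assay, 3,4,5-trimethoxyphenyl on the saturated chain carbon bound to an oxygen on an aromatic ring gives an intermediate result: modest steps from the two weaker compounds (a 2.1-fold lower number from compound 1 to compound 4 (0.31 log units; beyond the scatter); a 2.2-fold lower number from compound 2 to compound 4 (0.35 log units; beyond the scatter)) and a large gap to the 4-cyanophenyl compound (an 18-fold higher number from compound 3 to compound 4 (1.26 log units; beyond the scatter)). This position therefore gives more than the two levels seen earlier, yet adding three methoxy groups does not approach the low number of compound 3, which among these four compounds stands with 4-cyanophenyl alone. Nothing available explains this ranking.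

Going by these compounds, it remains open whether the low number of compound 3 depends on the nitrile or would also appear with another group on the ring, such as an amine or a carboxylic acid. A plain phenyl ring at this position would give all four compounds a common reference.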